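Mirror-Image Cyclopropyl Amide on a Bicyclic Diamine Core

The source may report more compounds than this note shows. Statements on the series, on what has been measured and on what is new or still open speak of the compounds shown alone.

Compound 3 `C[C@@H]1C[C@@H]1C(=O)N1CC2CC(C1)N2` holds the lowest number of the three measured compounds in an assay on CHO cells for displacement of a labelled ligand from Neuronal acetylcholine receptor; alpha3/alpha6/beta2/beta3 (Homo sapiens), read by scintillation counting (on this read-out higher numbers stand for weaker inhibition and lower numbers for stronger inhibition), at 92 nM. Compound 2 `CCC(=O)N1CC2CC(C1)N2` gives 190 nM and compound 1 `CC(=O)N1CC2CC(C1)N2` gives 610 nM. The steps leading to compound 3 were modest: a 6.6-fold lower number from compound 1 to compound 3 (0.82 log units; beyond the scatter) and a 2.1-fold lower number from compound 2 to compound 3 (0.31 log units; beyond the scatter), alongside a 3.2-fold lower number from compound 1 to compound 2 (0.51 log units; beyond the scatter). Compound 4 `C[C@H]1C[C@H]1C(=O)N1CC2CC(C1)N2` differs from compound 3 only in configuration: the two compounds have the same atoms and bonds; at least one stereo element is drawn with a configuration in one of them and without one in the other: 2 of 4 stereo elements differ; a stereocentre at a saturated ring carbon is drawn R in compound 3 and S in compound 4; a stereocentre at a saturated ring carbon is drawn S in compound 3 and R in compound 4. Going by the values given here, none of the measured steps alters a stereocentre, so they set no direction for this change; the two compounds may read alike in this assay, or one may lag behind the other. For compound 4 the estimated value in this assay is 160 nM, within an expected range of 50 nM to 600 nM. That estimate corresponds to an expected step of a 1.7-fold higher number from compound 3 to compound 4 (0.24 log units; within the scatter).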

Compound 4, inhibition constant: 170 nM
Beside the measured number, compound 4's estimate is 1.1-fold (0.03 log units) below it; the measured number falls inside the stated range.
By their numbers in this assay, from the lowest: compounds 3, 4 and 2 (each within the scatter of the next, the first and the last beyond it); then compound 1.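

Reversing both ring stereocentres of the 2-methylcyclopropyl group moves the number only within the scatter, with a 1.8-fold higher number from compound 3 to compound 4 (0.27 log units; within the scatter), so this position shows no clear preference between the two drawn configurations. Against ethyl, the mirror-image group also stays within the scatter, with a 1.1-fold lower number from compound 2 to compound 4 (0.05 log units; within the scatter), whereas against methyl it holds a step beyond it, with a 3.6-fold lower number from compound 1 to compound 4 (0.55 log units; beyond the scatter). Only the configuration of compound 3 therefore has a printed step beyond the scatter from ethyl. As far as these compounds go, how cyclobutyl or phenyl would read on the carbonyl carbon stays open. Whether the two configurations truly read alike also stays uncertain because of one fact: the fact that one of compounds 3 and 4 is drawn with a defined configuration and the other without, at the place where they differ.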